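Furan in Place of Phenyl on the Thiazole Carbon

The compounds below may be only part of what the source reports. "The series", "measured", "known", "first", "only" and "open" are said of these compounds alone.

Compound 2 `Nc1nc(-c2ccccc2)nc2sc(-c3ccccc3)nc12` gives the lower of the two numbers seen so far in an assay on CHO cells for displacement of a labelled ligand from adenosine receptor A3 (Homo sapiens), read by scintillation counting, with a stated time of 3 h; on this read-out lower numbers stand for stronger inhibition and higher numbers for weaker inhibition; its neighbour compound 1 `Cc1nc(N)c2nc(-c3ccccc3)sc2n1` gives 2660 nM against 84 nM for compound 2. Within the data shown here, the only measured step, a 32-fold lower number from compound 1 to compound 2 (1.50 log units; beyond the scatter), concerns the other ring position, so it does not bear directly on the present change. Compound 3 `Nc1nc(-c2ccccc2)nc2sc(-c3ccco3)nc12` differs from compound 2 by furan-2-yl in place of phenyl on an aromatic carbon. With an aromatic ring retained at that place, the expected step is a 1.4-fold higher number from compound 2 to compound 3 (0.15 log units; within the scatter), small and within the scatter. Compound 3 is therefore estimated at 120 nM, in a range from 40 nM to 400 nM.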

Compound 3, inhibition constant: 15 nM
Compound 3: middle estimate off by 8.0-fold (0.90 log units), on the high side; measured number below the stated range.
By their numbers in this assay, from the lowest: compound 3; then compound 2; then compound 1.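

Replacing phenyl with furan-2-yl on this aromatic carbon gives a 5.6-fold lower number from compound 2 to compound 3 (0.75 log units; beyond the scatter) in this assay. The position therefore distinguishes between two aromatic rings, and keeping an aromatic ring there does not by itself hold the number steady. No measurement at hand accounts for the difference.

The compounds shown leave open whether the step comes from the ring oxygen or the smaller ring, and what a thiophene ring or an amine would give at this carbon. From the compounds shown here alone, whether the same step would appear with the methyl of compound 1 at the other ring position also stays open.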